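Inverting one ring stereocentre: compound 2 to compound 4

The compounds below may be only part of what the source reports. "The series", "measured", "known", "first", "only" and "open" are said of these compounds alone.

Measured in a functional assay on EC9706 cells (Homo sapiens) for antiproliferative activity, read by MTT assay, with a stated time of 48 h; on this read-out lower numbers stand for stronger inhibition and higher numbers for weaker inhibition:
compound 1 `CCCCCCCCCCn1cc(COC[C@@H]2OC[C@H](N)[C@@H]2O)nn1` gives 15600 nM
compound 2 `CCCCCCCCCCCCn1cc(COC[C@@H]2OC[C@H](N)[C@@H]2O)nn1` gives 16000 nM
compound 3 `CCCCCCCCCCCCCCCCCCn1cc(COC[C@@H]2OC[C@H](N)[C@@H]2O)nn1` gives 17800 nM

Compound 2 cannot be separated from the other two measured compounds. The values show a 1.0-fold higher number from compound 1 to compound 2 (0.01 log units; within the scatter) and a 1.1-fold higher number from compound 2 to compound 3 (0.05 log units; within the scatter), so all three sit at one level.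

Compound 4 `CCCCCCCCCCCCn1cc(COC[C@@H]2OC[C@H](N)[C@H]2O)nn1` has the same atoms and bonds as compound 2 and differs only in configuration as drawn. The counted difference is the two compounds have the same atoms and bonds and differ only in configuration as drawn: 1 of 3 stereo elements differ; a stereocentre at a saturated ring carbon is drawn S in compound 2 and R in compound 4 and a stereocentre at a saturated ring carbon is drawn S in compound 2 and R in compound 4.

The measured steps all change the chain and leave the configuration alone, so they bear on this change only indirectly. Even the step spanning the series, a 1.1-fold higher number from compound 1 to compound 3 (0.06 log units; within the scatter), stays within the scatter. Among the compounds with values here, no measured pair isolates a change of configuration, so the size of this step is poorly constrained. With no evidence for a direction, no shift beyond the scatter is expected in this assay, though a wide range is kept. The expected step is no change at the digits printed from compound 2 to compound 4 (within the scatter) in this estimate. Compound 4 is estimated at 16000 nM (expected range 7000 nM to 35000 nM).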

Compound 4, half-maximal inhibitory concentration: 93800 nM
The estimate for compound 4 lay 5.9-fold (0.77 log units) below the measured number; measured number above the stated range.
By their numbers in this assay, from the lowest: compounds 1, 2 and 3 (each within the scatter of the next); then compound 4.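

In this assay, the configuration at this saturated ring carbon matters in a way that chain length did not: a 5.9-fold higher number from compound 2 to compound 4 (0.77 log units; beyond the scatter). Within the data shown here, the steps among compounds 1, 2 and 3 all stayed within the scatter, so this is the only step that lies beyond it, and it runs towards weaker inhibition, with compound 4 as the weakest of the four. The shift can be assigned to this single stereocentre alone, since neither the chain nor any other group changes and the other stereo elements stay as drawn: the fact that compounds 2 and 4 differ only in the configuration as drawn.

From the compounds shown here alone, this rests on one pair, so it remains open whether the same inversion carries a step of similar size on the chains of compound 1 and compound 3, or on a chain much shorter than any of these, and whether inverting either of the other two stereo elements matters as much. Going by these compounds, it is also open how the drawn configuration of compound 2 would compare with that of compound 4 if an acetamide or a carboxylic acid stood in place of the amine on the shared core.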